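The compounds below may be only part of what the source reports. "The series", "measured", "known", "first", "only" and "open" are said of these compounds alone.

In a functional assay for inhibition, with Homo sapiens as the target (on this read-out lower numbers stand for stronger inhibition and higher numbers for weaker inhibition), compound 1 (`Cc1cc2c(cc1C(=O)N=C(N)N)S(=O)(=O)CCC2C`) gives 655 nM, compound 2 (`CCC1(O)CS(=O)(=O)c2cc(C(=O)N=C(N)N)c(C)cc21`) gives 77 nM and compound 3 (`CCC1CS(=O)(=O)c2cc(C(=O)N=C(N)N)c(C)cc21`) gives 78 nM. Compound 3 thus stands level with compound 2, within the scatter, while compound 1 shows a clearly higher number, with weaker inhibition.

Compound 4 (`COC1CS(=O)(=O)c2cc(C(=O)N=C(N)N)c(C)cc21`) has not yet been measured. It carries methoxy in place of ethyl on a saturated ring carbon, two ring bonds from the ring sulfur: methoxy in place of ethyl on a saturated ring carbon. Going by the values given here, no measured pair makes this exact swap. The nearest evidence is a 1.0-fold higher number from compound 2 to compound 3 (0.01 log units; within the scatter), a step within the scatter in which hydrogen takes the place of hydroxy on a saturated ring carbon. That single step shows that one change on a saturated ring carbon left the number unmoved, but it cannot settle the effect of losing ethyl. In this assay, little movement is therefore expected, with a slight lean towards a higher number. The expected step is a 1.4-fold higher number from compound 3 to compound 4 (0.15 log units; within the scatter), which would stay within the scatter. For compound 4 the estimated value is 110 nM, with an expected range from 40 nM to 320 nM.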

Compound 4, half-maximal inhibitory concentration: 208 nM
Compound 4: middle estimate off by 1.9-fold (0.28 log units), on the low side; measured number inside the range.
By their numbers in this assay, from the lowest: compounds 2 and 3 (each within the scatter of the next); then compound 4; then compound 1.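

In this assay, methoxy in place of ethyl gives a 2.7-fold higher number from compound 3 to compound 4 (0.43 log units; beyond the scatter), a modest step but one beyond the scatter. The saturated ring carbon two ring bonds from the ring sulfur is therefore not indifferent to every change, although the swap of hydrogen for hydroxy on that carbon, with ethyl kept, had left the number unmoved. Here the number rises even though the two groups have the same count of heavy atoms, and the entering methoxy adds one hydrogen-bond acceptor where ethyl has none.

Nothing at hand explains why this swap weakens inhibition. On these data alone, it remains open how a longer chain such as propyl, or an amine on the same carbon, would compare with ethyl and methoxy.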